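A few compounds are considered here, and "the series" means these few. Any claim that something is new, unique, unknown or untested is made for them only; others in the source may bear on it.

Of the compounds shown here, two sharing one core have been measured in an assay on CHO cells for displacement of a labelled ligand from adenosine receptor A3 (Homo sapiens), read by scintillation counting, tested at 10 uM; on this read-out higher numbers stand for more inhibition at the one concentration tested (going by the name of the read-out) and lower numbers for less inhibition. Compound 1 `CC(C)(C)Cc1c(-c2cccnc2)sc(N)c1C(=O)c1ccc(Cl)cc1` carries a pyridin-3-yl group on an aromatic carbon of its five-membered ring, and in this assay compound 1 gives 1%. Compound 2 `CC(C)(C)Cc1c(Br)sc(N)c1C(=O)c1ccc(Cl)cc1` carries a bromo in its place, and in this assay compound 2 gives 1%. Within the data shown here, the single step between them, no change at the digits printed from compound 1 to compound 2 (within the scatter), shows that putting bromo in place of pyridin-3-yl left the read-out unchanged; both compounds sit at the very bottom of the scale, and compound 2 stands level with compound 1.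

Compound 3 `COc1ccc(-c2sc(N)c(C(=O)c3ccc(Cl)cc3)c2CC(C)(C)C)cc1` is the one not yet measured. It differs from compound 2 in one place: 4-methoxyphenyl in place of bromo on an aromatic carbon. Among the measured compounds shown here, the only measured step that bears on this change is no change at the digits printed from compound 1 to compound 2 (within the scatter), which removed one aromatic ring from this carbon without effect beyond the scatter. Returning a ring to the same aromatic carbon is therefore expected to give a step of about a number 2 percentage points higher from compound 2 to compound 3 (within the scatter), nothing beyond the scatter. Compound 3 is accordingly estimated at 3%, with a range from -8% to 18%.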

Compound 3, a percentage reported as inhibition, at one concentration (the size of the read-out at that concentration, not a potency): 2%
The estimate for compound 3 lay 1 percentage points above the measured number; the measured number falls inside the stated range.
By their numbers in this assay, from the lowest: compounds 1, 2 and 3 (each within the scatter of the next).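

In this assay, the aromatic carbon next to the ring sulfur now carries a third kind of group, 4-methoxyphenyl, and the steps are a number 1 percentage points higher from compound 2 to compound 3 (within the scatter) and a number 1 percentage points higher from compound 1 to compound 3 (within the scatter). Across these three compounds, the read-out therefore stays at the bottom of the scale with a single bromine atom, a pyridin-3-yl ring or a 4-methoxyphenyl ring on this carbon, so a six-membered aromatic ring made only of carbon and bearing a methoxy group does no more here than the ring of compound 1 or the bromo of compound 2. No measurement is available that explains this flat result.

The compounds shown leave open whether any other kind of group on this carbon, such as a carboxylic acid, a piperidine or a longer alkyl chain, would lift the read-out clear of the scatter. They also leave open what happens when the core changes elsewhere, for example with an ethyl group in place of the neopentyl group, since all three compounds keep that group and the amino group unchanged.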